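Chain Variation at the Aromatic Nitrogen of a Shared Core

This account rests on a few compounds, and the source may have more. Where it says the series, first, only, none or still open, it means among the compounds named here.

compound 1: `CN(C)S(=O)(=O)CCn1c(=N)sc2cc(OC(F)(F)F)ccc21`, > 10 mg/kg
compound 2: `CSCn1c(=N)sc2cc(OC(F)(F)F)ccc21`, 3 mg/kg

The two measured compounds share one core and differ only in the chain on the aromatic nitrogen. Within the data shown here, in a functional assay on the whole organism with Rattus norvegicus as the target (on this read-out higher numbers stand for an effect only at larger amounts of compound and lower numbers for an effect already at smaller amounts), compound 2 gives 3 mg/kg, the only actual number among the values shown. Compound 1 reaches only a limit of the assay, > 10 mg/kg. Among the measured compounds shown here, the single measured step, an at least 3.3-fold lower number from compound 1 to compound 2 (0.52 log units; beyond the scatter), therefore rests on the limit (the limit of > 10 mg/kg in this assay, at which 1 of the 2 values shown sits).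

Compound 3, `C[S+]([O-])CCCn1c(=N)sc2cc(OC(F)(F)F)ccc21`, is not yet measured; it carries a group of 5 heavy atoms (3 carbon, 1 oxygen, 1 sulfur; no ring) in place of a group of 2 heavy atoms (1 carbon, 1 sulfur; no ring), on a saturated chain carbon bound to an aromatic nitrogen. This change bears on that one step, since the longer chain of compound 1 gave the limit of > 10 mg/kg in this assay, at which 1 of the 2 values shown sits, while the small methylsulfanyl of compound 2 gave 3 mg/kg. A step upward is therefore expected in this assay, a 2.7-fold higher number from compound 2 to compound 3 (0.43 log units; beyond the scatter), though the chain of compound 3 is not that of compound 1 and the size is uncertain. Compound 3 is expected to give 8 mg/kg, between 3 mg/kg and 30 mg/kg.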

Compound 3, dose for half-maximal effect: 2.3 mg/kg
Estimate against measurement, compound 3: 3.5-fold (0.54 log units) above, outside the stated range (below it).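

In this assay the longer chain of compound 3 gives a 1.3-fold lower number from compound 2 to compound 3 (0.12 log units; within the scatter), so the group of 5 heavy atoms and the methylsulfanyl cannot be told apart on this read-out. The other new step, an at least 4.3-fold lower number from compound 1 to compound 3 (0.63 log units; beyond the scatter), rests on a limit of the assay: the limit of > 10 mg/kg in this assay, at which 1 of the 3 values shown sits A longer chain on a saturated chain carbon bound to an aromatic nitrogen therefore does not by itself go with the limit seen for compound 1, and among these three compounds that limit goes with the (dimethylsulfamoyl)methyl of compound 1.

The compounds shown leave open whether an amine or a carboxylic acid at the end of the chain, or a still longer chain, would keep this level of effect. As far as these compounds go, with no actual number for compound 1, the full size of its gap to the other two remains unknown.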